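Ester to Amide at the Chain End of a Urea Series

The source may hold more compounds than are shown below. What is called first, only, known or untested is meant among the compounds shown, and "the series" means these compounds.

Compound 1, `O=C(NCc1ccc(C(=O)N2CCCCc3ccccc32)c(F)c1)Nc1c(F)cccc1F`: 180 nM
Compound 2, `Cc1cc(C(=O)N2CCCCc3ccccc32)ccc1CNC(=O)Nc1c(F)cccc1F`: 2.1 nM
Compound 3, `CCOC(=O)CNC(=O)NCc1ccc(C(=O)N2CCCCc3ccccc32)cc1C`: 140 nM

These three compounds share a core and were tested in a functional assay on HEK293 cells for agonist activity at Vasopressin V2 receptor (Homo sapiens), read by a luciferase reporter and cAMP accumulation; on this read-out lower numbers stand for an effect already at smaller amounts and higher numbers for an effect only at larger amounts of compound. Compound 3 stands second highest of the three numbers; its nearest neighbour is compound 1, a gap that lies within the scatter, while compound 2 is far away, with a 67-fold higher number from compound 2 to compound 3 (1.82 log units; beyond the scatter).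

Compound 4, `Cc1cc(C(=O)N2CCCCc3ccccc32)ccc1CNC(=O)NCC(=O)N(C)C`, has not yet been measured. It differs from compound 3 in one place: dimethylamino in place of ethoxy on a carbonyl carbon. Within the data shown here, no measured step touches this carbonyl carbon; the only step known concerns a different part of the chain, the swap of the 2,6-difluorophenyl for the (ethoxycarbonyl)methyl group, and so it gives no direct guide here. Without a comparable step, the expectation is no change beyond the scatter: compound 4 is estimated at 150 nM, within 50 nM to 450 nM, which means an expected step of a 1.1-fold higher number from compound 3 to compound 4 (0.03 log units; within the scatter).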

Compound 4, half-maximal effective concentration: 58 nM
The estimate for compound 4 lay 2.6-fold (0.41 log units) above the measured number; low and high end bracket the measured number.
By their numbers in this assay, from the lowest: compound 2; then compound 4; then compounds 3 and 1 (each within the scatter of the next).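

Compound 3 and compound 4 show that the group on this carbonyl carbon can shift the result: in this assay, dimethylamino in place of ethoxy gives a 2.4-fold lower number from compound 3 to compound 4 (0.38 log units; beyond the scatter) and this modest step lies beyond the scatter. The change recovers only a small part of what is lost without the 2,6-difluorophenyl, since (dimethylcarbamoyl)methyl in its place on the amide-type nitrogen still gives a 28-fold higher number from compound 2 to compound 4 (1.44 log units; beyond the scatter) while (ethoxycarbonyl)methyl gives a 67-fold higher number from compound 2 to compound 3 (1.82 log units; beyond the scatter) in the same comparison. Nothing available explains why the dimethylamino compound gives the lower number.

Still open, on these data alone, is how a carboxylic acid, a primary amide or a ring amine such as morpholine on this carbonyl carbon would compare with dimethylamino. A longer chain leading to the dimethylcarbamoyl group is equally untested among the compounds shown.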